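The source may hold more compounds than are shown below. What is called first, only, known or untested is meant among the compounds shown, and "the series" means these compounds.

Measured so far in an assay for inhibition of serine/threonine-protein kinase 3 (Homo sapiens), read by luminescence and ADP-Glo, in the presence of a further agent that is not named here; on this read-out lower numbers stand for stronger inhibition and higher numbers for weaker inhibition:
- compound 1 `OCCCNc1ncnc2[nH]cc(-c3cccc(Cl)c3)c12` gives 173 nM
- compound 2 `CC1(O)CCN(c2ncnc3[nH]cc(-c4cccc(Cl)c4)c23)CC1` gives 189 nM

Compound 2 has the higher of the two numbers, but the gap to compound 1 is within the scatter, so the two cannot be told apart on this read-out. The unmeasured compound 3 `CN(C)c1ncnc2[nH]cc(-c3cccc(Cl)c3)c12` is reached from compound 2 by one change: dimethylamino in place of 4-hydroxy-4-methylpiperidin-1-yl on an aromatic carbon. Going by the values given here, the only measured step that bears on this spot is a 1.1-fold higher number from compound 1 to compound 2 (0.04 log units; within the scatter), where a chain amine was swapped for a ring amine with no change beyond the scatter. Among the compounds with values here, that step suggests the group on this aromatic carbon has had little influence on the numbers so far. For compound 3 the step is therefore expected to stay within the scatter, as a 1.3-fold higher number from compound 2 to compound 3 (0.12 log units; within the scatter). The estimate for compound 3 in this assay is 250 nM, with a range of 100 nM to 700 nM.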

Compound 3, half-maximal inhibitory concentration: 349 nM
Compound 3: middle estimate off by 1.4-fold (0.14 log units), on the low side, and the stated range covers the measured number.
By their numbers in this assay, from the lowest: compounds 1, 2 and 3 (each within the scatter of the next).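

In this assay, the swap to dimethylamino, which has no ring and no hydrogen-bond donor, gives a 1.8-fold higher number from compound 2 to compound 3 (0.27 log units; within the scatter), and the swap from the (3-hydroxypropyl)amino group gives a 2.0-fold higher number from compound 1 to compound 3 (0.30 log units; within the scatter). Across these three compounds, then, neither the hydroxy group of compound 1 and compound 2 nor the ring of compound 2 is shown to matter on this aromatic carbon, since even the small dimethylamino group stays within the scatter of both. No supporting measurement is available to explain how these groups act at this position.

On these data alone, it remains open whether a quite different group here, such as an unsubstituted amino group or a longer chain ending in a carboxylic acid, would move the number beyond the scatter. All three compounds share the rest of their structure, so they say nothing about changes elsewhere on the core.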